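Methyl to fluoro on the benzyloxy ring: two settings

The source may hold more compounds than are shown below. What is called first, only, known or untested is meant among the compounds shown, and "the series" means these compounds.

Compound 1: `Cc1cccc(COc2ccc(-c3cc(CN4CCN(Cc5ccc(C(F)(F)F)cc5)CC4)no3)cc2)c1`, 4000 nM
Compound 2: `Fc1cccc(COc2ccc(-c3cc(CN4CCN(Cc5ccc(C(F)(F)F)cc5)CC4)no3)cc2)c1`, 2500 nM
Compound 3: `Cc1cc(-c2cc(CN3CCN(Cc4ccc(C(F)(F)F)cc4)CC3)no2)ccc1OCc1cccc(C#N)c1`, 700 nM

In a functional assay on MCF7 cells (Homo sapiens) for antiproliferative activity, read by sulforhodamine B assay, with a stated time of 72 h (on this read-out lower numbers stand for stronger inhibition and higher numbers for weaker inhibition), compound 1 gives 4000 nM, and compound 2 gives 2500 nM. The two differ only by fluoro in place of methyl on an aromatic carbon, and the step of a 1.6-fold lower number from compound 1 to compound 2 (0.20 log units; within the scatter) lies within the scatter, so the two values cannot be ordered.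

Compound 3 gives 700 nM in this assay and stands lowest of the three, beyond the scatter from both compound 1 and compound 2. How its core differs from that of compound 1 is not broken down here.

Compound 4, `N#Cc1cccc(COc2ccc(-c3cc(CN4CCN(Cc5ccc(C(F)(F)F)cc5)CC4)no3)cc2F)c1`, is not yet measured. It differs from compound 3 by fluoro in place of methyl on an aromatic carbon. This is the same kind of change as that from compound 1 to compound 2, but not the same: in compound 4 the fluoro sits ortho to a (3-cyanobenzyl)oxy group and meta to a large group, whereas in compound 2 it sits only meta to a large group.

For compound 4 in this assay the step of a 1.3-fold lower number from compound 3 to compound 4 (0.10 log units; within the scatter) is expected, resting on the step of a 1.6-fold lower number from compound 1 to compound 2 (0.20 log units; within the scatter), which stayed within the scatter. Compound 4 is therefore estimated at 550 nM, between 250 nM and 1400 nM.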

Compound 4, half-maximal inhibitory concentration: 380 nM
Compound 4: the middle estimate sits 1.4-fold (0.16 log units) above what was measured; the measured number falls inside the stated range.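

In this assay the new step, a 1.8-fold lower number from compound 3 to compound 4 (0.27 log units; within the scatter), stays within the scatter, so the two values cannot be ordered. Set beside the earlier step, fluoro in place of methyl gives the same reading on both cores, with neither step leaving the scatter and no difference between the two steps: the same change on two cores in this assay, a 1.6-fold lower number (0.20 log units; within the scatter) from compound 1 to compound 2 and a 1.8-fold lower number (0.27 log units; within the scatter) from compound 3 to compound 4, 1.2-fold (0.06 log units) apart, within the scatter of two such steps This shows that the change carried over from the core of compound 1 to the core of compound 3 with no difference that can be read, even though in compound 4 the fluoro sits ortho to a (3-cyanobenzyl)oxy group; it does not show that fluoro gives a real gain on either core, nor that the same would hold on any core beyond these two.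

The compounds shown leave open what a chloro, a methoxy or a plain hydrogen would give on that same aromatic carbon of the core of compound 3. They also leave open whether the change would still read the same if the trifluoromethyl group were replaced, for instance by a chloro or a carboxylic acid.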